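The source may hold more compounds than are shown below. What is called first, only, known or untested is meant among the compounds shown, and "the series" means these compounds.

Measured compounds:
Compound 1, `CC(C)(C)[C@@H](O)C(=O)N1C[C@@H]2C[C@@H]2[C@H]1C(=O)NCc1cc(Cl)ccc1-n1cnnn1`, gives a value that is a limit of the assay, < 15 mL.min-1.g-1.
Compound 2, `CC(C)(C)C[C@@H](O)C(=O)N1C[C@@H]2C[C@@H]2[C@H]1C(=O)NCc1cc(Cl)ccc1-n1cnnn1`, gives 20 mL.min-1.g-1.
Compound 3, `CC(C)(C)[C@@H](O)C(=O)N1[C@H](C(=O)NCc2cc(Cl)ccc2-n2cnnn2)C[C@@H]2C[C@@H]21`, gives 75 mL.min-1.g-1.

All three were run in an ADME assay on liver for metabolic stability, with Liver microsome (Homo sapiens) as the target, read by LC-MS, using microsomes; on this read-out higher numbers stand for fast clearance and lower numbers for slow clearance. Compound 1 and compound 3 are built from the same atoms joined differently; the difference between the two cores is not broken down here. Compound 3 stands highest of the two numbers, and its nearest neighbour is compound 2. Compound 2 differs from compound 1 by neopentyl in place of tert-butyl on a saturated chain carbon bound to a carbonyl carbon and an oxygen on a saturated carbon, and that change gave an at least 1.3-fold higher number from compound 1 to compound 2 (0.12 log units; that floor lies within the scatter); the floor of that step rests on (the limit of < 15 mL.min-1.g-1 in this assay, at which 1 of the 3 values shown sits).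

Compound 4, `CC(C)(C)C[C@@H](O)C(=O)N1[C@H](C(=O)NCc2cc(Cl)ccc2-n2cnnn2)C[C@@H]2C[C@@H]21`, is not yet measured in this assay. It differs from compound 3 by neopentyl in place of tert-butyl on a saturated chain carbon bound to a carbonyl carbon and an oxygen on a saturated carbon, the same change in the same place as that from compound 1 to compound 2. Because the step of an at least 1.3-fold higher number from compound 1 to compound 2 (0.12 log units; that floor lies within the scatter) was small, the account expects from compound 3 to compound 4 a step of about a 1.3-fold higher number from compound 3 to compound 4 (0.10 log units; within the scatter) in this assay. Compound 4 is therefore estimated at 95 mL.min-1.g-1, with a likely range from 45 mL.min-1.g-1 to 190 mL.min-1.g-1.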

Compound 4, intrinsic clearance in microsomes: 40 mL.min-1.g-1
Beside the measured number, compound 4's estimate is 2.4-fold (0.38 log units) above it, and the stated range ends above it.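

In this assay, neopentyl in place of tert-butyl on the core of compound 3 gave a 1.9-fold lower number from compound 3 to compound 4 (0.27 log units; within the scatter), so on this core the two groups cannot be told apart. This does not show that the change carries from one core to the other unaltered, and it does not show that the change behaves differently on the two cores: the same change on two cores in this assay, an at least 1.3-fold higher number (0.12 log units; that floor lies within the scatter) from compound 1 to compound 2 and a 1.9-fold lower number (0.27 log units; within the scatter) from compound 3 to compound 4; the limit leaves it open whether they differ

Compound 1 gives < 15 mL.min-1.g-1, which is a limit of the assay and not a number: the limit of < 15 mL.min-1.g-1 in this assay, at which 1 of the 4 values shown sits.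

The compounds shown carry only tert-butyl and neopentyl in this place, so they leave open how a longer chain or a cyclohexyl group would read in this assay on either core. They also leave open whether an amine in place of the hydroxyl group on the saturated chain carbon would give a different read-out on the core of compound 1 or on that of compound 3.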